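The source may report more compounds than this note shows. Statements on the series, on what has been measured and on what is new or still open speak of the compounds shown alone.

In a functional assay on MDA-MB-231 cells (Homo sapiens) for inhibition, read by MTT assay, with a stated time of 72 h (on this read-out higher numbers stand for weaker inhibition and lower numbers for stronger inhibition), compound 1, with structure `CC(C)[C@H](NC(=O)c1cc(Cl)ccc1OCCNC(=O)OC(C)(C)C)C(=O)Nc1cc(F)cc(C(F)(F)F)c1`, gives 7870 nM. Compound 2, with structure `CC(C)[C@H](NC(=O)c1cc(Cl)ccc1OCCN)C(=O)Nc1cc(F)cc(C(F)(F)F)c1`, carries the change hydrogen in place of tert-butoxycarbonyl on an amine nitrogen relative to compound 1, and in this assay compound 2 gives 4340 nM. The step of a 1.8-fold lower number from compound 1 to compound 2 (0.26 log units; within the scatter) is therefore small, and the two values cannot be ranked against each other with confidence.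

Compound 3, with structure `CC(C)(C)OC(=O)NCCOc1ccc(Cl)cc1C(=O)NCC(=O)Nc1ccc2c(c1)S(=O)(=O)C=C2`, is built on a different core; how the core of compound 3 differs from the core of compound 1 is not broken down here. In this assay compound 3 gives 2080 nM, the lowest of the three measured numbers, and its steps to compound 2 and to compound 1 both lie beyond the scatter.

Compound 4, with structure `NCCOc1ccc(Cl)cc1C(=O)NCC(=O)Nc1ccc2c(c1)S(=O)(=O)C=C2`, has not yet been measured. It differs from compound 3 by hydrogen in place of tert-butoxycarbonyl on an amine nitrogen. This is the same change that separates compound 1 from compound 2, made at the same kind of place, an amine nitrogen whose other neighbour is a saturated chain carbon, so it appears twice among these four compounds.

Among the measured compounds shown here, the expectation for compound 4 rests on the only earlier example of this change: the step from compound 1 to compound 2 was a 1.8-fold lower number from compound 1 to compound 2 (0.26 log units; within the scatter), a small movement toward a lower number. A step of similar size is expected from compound 3 to compound 4, namely a 1.5-fold lower number from compound 3 to compound 4 (0.17 log units; within the scatter), because that single precedent gave a 1.8-fold lower number from compound 1 to compound 2 (0.26 log units; within the scatter). For the measured compounds named here, with only one precedent the band must stay wide. Compound 4 is thus estimated to give about 1400 nM in this assay, most likely between 600 nM and 3300 nM.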

Compound 4, half-maximal inhibitory concentration: 6370 nM
Beside the measured number, compound 4's estimate is 4.6-fold (0.66 log units) below it; measured number above the stated range.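

Taking off the tert-butoxycarbonyl group to leave the free 2-aminoethyl chain gives, in this assay, a 3.1-fold higher number from compound 3 to compound 4 (0.49 log units; beyond the scatter), which means weaker inhibition on the core of compound 3. The change therefore cannot be carried from one core to the other as a fixed shift, and a result on the core of compound 1 is a poor guide to its result on the core of compound 3: the same change on two cores in this assay, a 1.8-fold lower number (0.26 log units; within the scatter) from compound 1 to compound 2 and a 3.1-fold higher number (0.49 log units; beyond the scatter) from compound 3 to compound 4, 5.6-fold (0.74 log units) apart, beyond the scatter of two such steps This is not a clean reversal of direction, however, as the step on the core of compound 1 cannot be told from scatter, and two pairs cannot show which part of the cores makes the difference or how a third core would respond.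

From the compounds shown here alone, what remains open is whether other groups on the same amine nitrogen, such as an acetyl or a methyl group, would also separate the two cores, and whether a chain longer than 2-aminoethyl would behave the same way on each. It is also open whether the gap between the two cores would appear again in a different cell line, as everything shown here comes from this assay.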